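A few compounds are considered here, and "the series" means these few. Any claim that something is new, unique, unknown or untested is made for them only; others in the source may bear on it.

Among the measured compounds shown here, compound 2 `COc1ccc(-c2cc3ccccc3nc2/C=C/C(=O)c2ccco2)cc1` gives 640 nM in a functional assay on SK-BR-3 cells (Homo sapiens) for antiproliferative activity, read by XTT assay, with a stated time of 72 h (a higher number here means a weaker inhibitor, a lower number a stronger inhibitor), the lowest of the two numbers measured so far; the only neighbour is compound 1 `COc1ccc(-c2cc3ccccc3nc2/C=C/C(=O)c2ccc(N)cc2)cc1`, which gives 8560 nM in this assay, and the step between them is a 13-fold lower number from compound 1 to compound 2 (1.13 log units; beyond the scatter). Compound 3 `COc1ccc(-c2cc3ccccc3nc2/C=C/C(=O)c2cnc(N)nc2C)cc1` differs from compound 2 at the same place: 2-amino-4-methylpyrimidin-5-yl in place of furan-2-yl on a carbonyl carbon. For the measured compounds named here, the one measured step that bears on this change is the exchange of the aryl on the carbonyl carbon, which moved the number by a 13-fold lower number from compound 1 to compound 2 (1.13 log units; beyond the scatter) when 4-aminophenyl gave way to furan-2-yl. The group now entering is, like 4-aminophenyl in compound 1, a six-membered aromatic ring bearing an amino group, so the number for compound 3 is expected to move back toward that of compound 1, by a 4.7-fold higher number from compound 2 to compound 3 (0.67 log units; beyond the scatter). Compound 3 is thus estimated at 3000 nM in this assay, with a range of 1000 nM to 10000 nM.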

Compound 3, half-maximal inhibitory concentration: > 10000 nM
Compound 3 ended at the assay's limit; the forecaster's own chance of this, stated with the estimate: 10%; middle value at least 3.3-fold (0.52 log units) from the limit.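

For compound 3 the reading in this assay is a limit of the assay and not a number: the limit of > 10000 nM in this assay, at which 1 of the 3 values shown sits.

Even so, the position on the carbonyl carbon now has two six-membered aromatic rings bearing an amino group, and both give higher numbers than furan-2-yl: the new step is an at least 15-fold higher number from compound 2 to compound 3 (1.19 log units; beyond the scatter), which adds a second case to the earlier step in the opposite direction, a 13-fold lower number from compound 1 to compound 2 (1.13 log units; beyond the scatter). The remaining step is an at least 1.1-fold higher number from compound 1 to compound 3 (0.06 log units; that floor lies within the scatter), so 4-aminophenyl and 2-amino-4-methylpyrimidin-5-yl cannot be placed in any order.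

The compounds shown leave open whether the lower number of compound 2 goes with the five-membered ring or with the lack of an amino group. An unsubstituted phenyl or a thiophen-2-yl on the carbonyl carbon would separate these two readings.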